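The compounds below may be only part of what the source reports. "The series", "measured", "known", "first", "only" and "open" are said of these compounds alone.

In an ADME assay on microsomes from liver (Mus musculus) for metabolic stability, with a stated time of 10 min (on this read-out lower numbers stand for a less stable compound and higher numbers for a more stable compound), compound 2 `Cc1cccc(C)c1COC(c1ccc([C@]2(S(=O)(=O)c3ccc(F)cc3)CCN(C(=O)[C@H]3CC[C@H](C(=O)O)CC3)C2)cc1)(C(F)(F)F)C(F)(F)F` gives 77% and compound 1 `O=C(O)[C@H]1CC[C@H](C(=O)N2CC[C@](c3ccc(C(OCc4ccccc4OC(F)(F)F)(C(F)(F)F)C(F)(F)F)cc3)(S(=O)(=O)c3ccc(F)cc3)C2)CC1` gives 81%, so the two stand within the scatter of each other. Compound 3 `Cc1cccc(F)c1COC(c1ccc([C@]2(S(=O)(=O)c3ccc(F)cc3)CCN(C(=O)[C@H]3CC[C@H](C(=O)O)CC3)C2)cc1)(C(F)(F)F)C(F)(F)F` differs from compound 2 by fluoro in place of methyl on an aromatic carbon, with fluoro in place of methyl on an aromatic carbon, giving 2-fluoro-6-methylphenyl. For the measured compounds named here, the one measured step that bears on this is a number 4 percentage points lower from compound 1 to compound 2 (within the scatter), which alters the same aromatic group and stays within the scatter. No step beyond the scatter is therefore expected in this assay, and the estimated change is a number 1 percentage points higher from compound 2 to compound 3 (within the scatter). Compound 3 is expected at 78%, within an estimated range of 66% to 88%.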

Compound 3, percent of the compound remaining: 78%
For compound 3 middle estimate and measured number coincide at the digits printed; the measured number falls inside the stated range.
By their numbers in this assay, from the lowest: compounds 2, 3 and 1 (each within the scatter of the next).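

In this assay fluoro in place of methyl on an aromatic carbon, ortho to a large group, gives a number 1 percentage points higher from compound 2 to compound 3 (within the scatter) and so adds a second kind of change at this ring that stays within the scatter. Exchanging 2-(trifluoromethoxy)phenyl for 2-fluoro-6-methylphenyl gives a number 3 percentage points lower from compound 1 to compound 3 (within the scatter) as well, so none of the three aromatic groups shown separates from the others on this read-out. No supporting measurement bears on this result. Still open, on these data alone, is whether an amine or a nitrile on this aromatic ring would give a step beyond the scatter in this assay or whether it would stay within it.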